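This account rests on a few compounds, and the source may have more. Where it says the series, first, only, none or still open, it means among the compounds named here.

Of the compounds shown here, two of a shared core have so far been tested in a functional assay on SH-SY5Y cells (Homo sapiens) for cytotoxicity, read by MTT assay, with stated times of 8 h, 30 min and 12 h, tested at 0.05 uM; on this read-out higher numbers stand for a stronger effect at the one concentration tested and lower numbers for a weaker effect. Compound 1 `COc1ccc(CNC(=N)[C@@H]2CCC(=O)N2Cc2ccccc2)cc1` gives 7.1% in this assay. Compound 2 `COc1ccc(CN2C(=O)CC[C@H]2C(=N)NCc2ccccc2)cc1` gives 12.3% in this assay, which is the higher of the two numbers, though the gap to compound 1 lies within the scatter of repeated measurements, so the two compounds cannot be ranked against each other on what is shown.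

Compound 3 `COc1ccc(CNC(=N)[C@@H]2CCC(=O)N2Cc2ccc(OC)cc2)cc1` has not yet been measured. It differs from compound 2 in one place: methoxy in place of hydrogen on an aromatic carbon. Going by the values given here, no step between measured compounds of this kind is available, so the effect of this change has to be guessed from the two numbers alone, and since both lie close together, the step is expected to be small, with no direction beyond the scatter. Compound 3 is therefore estimated to give 10% in this assay, between 2% and 20%, a step of a number 2.3 percentage points lower from compound 2 to compound 3 (within the scatter).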

Compound 3, a percentage reported as activity, at one concentration (the size of the read-out at that concentration, not a potency): 24.2%
Estimate against measurement, compound 3: 14.2 percentage points below, and the stated range ends below it.
By their numbers in this assay, from the lowest: compounds 1 and 2 (each within the scatter of the next); then compound 3.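

In this assay, the change from benzyl to 4-methoxybenzyl now has a measurable effect, and it does so at both benzyl groups of the shared core: the methoxy gives a number 11.9 percentage points higher from compound 2 to compound 3 (beyond the scatter), and at the other benzyl group it gives a number 17.1 percentage points higher from compound 1 to compound 3 (beyond the scatter). Compounds 1 and 2 each carry one benzyl and one 4-methoxybenzyl and could not be ranked, whereas compound 3, with 4-methoxybenzyl in both places, stands clear of both. Nothing available explains this rise.

As far as these compounds go, what a hydroxyl group, a chlorine atom or a longer ethoxy chain would give in place of the methoxy remains open. So does the number for the shared core with plain benzyl in both places, which would show how the two methoxy groups add up.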